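Hydroxy on the chain of compound 2

The source may hold more compounds than are shown below. What is called first, only, known or untested is meant among the compounds shown, and "the series" means these compounds.

Measured in a functional assay on the whole organism with Mus musculus as the target; a higher number here means that more compound is needed for the effect, a lower number that less compound is needed:
- compound 1 (`CNC(=O)[C@@H](C)NCc1ccc(OCc2ccccc2)cc1`): 40.5 mg/kg
- compound 2 (`CNC(=O)[C@H](C)NCc1ccc(OCc2ccccc2)cc1`): 8.4 mg/kg

Compound 2 holds the lower number of the two, at 8.4 mg/kg. Compound 3 (`CNC(=O)[C@H](CO)NCc1ccc(OCc2ccccc2)cc1`) turns its methyl into hydroxymethyl, with hydroxy in place of hydrogen on a saturated chain carbon, two bonds along the chain from an amine nitrogen and a carbonyl carbon. Among the measured compounds shown here, only one measured step bears on this, a 4.8-fold lower number from compound 1 to compound 2 (0.68 log units; beyond the scatter), and it is a matter of configuration alone (the fact that compounds 1 and 2 differ only in the configuration as drawn). That step shows a modest response to a change at a stereocentre on a saturated chain carbon, but no substituent has been tested. A modest rise of similar size is expected in this assay, estimated as a 2.4-fold higher number from compound 2 to compound 3 (0.38 log units; beyond the scatter). For compound 3 the estimated value is 20 mg/kg, with an expected range of 6 mg/kg to 70 mg/kg.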

Compound 3, dose for half-maximal effect: 15 mg/kg
Estimate against measurement, compound 3: 1.3-fold (0.12 log units) above; low and high end bracket the measured number.
By their numbers in this assay, from the lowest: compounds 2 and 3 (each within the scatter of the next); then compound 1.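

In this assay, hydroxy in place of hydrogen on this saturated chain carbon gives a 1.8-fold higher number from compound 2 to compound 3 (0.25 log units; within the scatter), so this first substituent read at the position brings no change beyond the scatter. The hydroxymethyl form also stays clear of the other methyl stereoisomer, with a 2.7-fold lower number from compound 1 to compound 3 (0.43 log units; beyond the scatter). The earlier contrast at this carbon concerned configuration alone: the fact that compounds 1 and 2 differ only in the configuration as drawn

On these data alone, whether the hydroxy group itself matters stays open, and a methoxymethyl, an aminomethyl or a longer chain would test how much this position accepts. As far as these compounds go, the effect of the opposite configuration on the hydroxymethyl form also remains open.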